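A few compounds are considered here, and "the series" means these few. Any claim that something is new, unique, unknown or untested is made for them only; others in the source may bear on it.

Of the compounds shown here, three of this set have been measured in a physicochemical assay for lipophilicity; on this read-out higher numbers stand for higher lipophilicity and lower numbers for lower lipophilicity. Compound 1 `COc1ccc(C2SCC(=O)N2NC(=O)CNC(=O)c2ccccc2)cc1OC` gives 1.85, compound 2 `O=C(CNC(=O)c1ccccc1)NN1C(=O)CSC1c1ccc(F)cc1` gives 2.1, and compound 3 `O=C(CNC(=O)c1ccccc1)NN1C(=O)CSC1c1ccccc1Cl` gives 2.3, the highest of the three. Compound 2 lies nearest, the step of a number 0.20 log units higher from compound 2 to compound 3 (within the scatter); compound 1 lies furthest, and the gap between compound 1 and compound 3 is beyond the scatter.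

Compound 4 `O=C(CNC(=O)c1ccccc1)NN1C(=O)CSC1c1ccc(O)cc1` differs from compound 3 in one place: 4-hydroxyphenyl in place of 2-chlorophenyl on a saturated ring carbon. Among the compounds with values here, the only measured step on this carbon exchanges one halogenated phenyl for another and is within the scatter; no measured step introduces a hydrogen-bond donor here. A step downward beyond the scatter is nevertheless expected, a number 1.00 log units lower from compound 3 to compound 4 (beyond the scatter), placing compound 4 at an estimated 1.3, between 0.9 and 1.7.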

Compound 4, partition coefficient: 1.75
Beside the measured number, compound 4's estimate is 0.45 log units below it, outside the stated range (above it).
By their numbers in this assay, from the lowest: compounds 4, 1, 2 and 3 (each within the scatter of the next, the first and the last beyond it).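

In this assay, within the data shown here, the saturated ring carbon shows for the first time a single change that passes the scatter: 4-hydroxyphenyl in place of 2-chlorophenyl gives a number 0.55 log units lower from compound 3 to compound 4 (beyond the scatter) and so goes further than the exchange of one halogenated phenyl for another. Hydroxy in place of fluoro on an aromatic carbon gives a number 0.35 log units lower from compound 2 to compound 4 (beyond the scatter) so the step downward appears from both halogenated phenyls. Nothing available accounts for these steps. The compounds shown leave open how an amine or a carboxylic acid on this phenyl would compare with hydroxy.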